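Shifting One Methyl Group Around a Phenyl Ring

The source may report more compounds than this note shows. Statements on the series, on what has been measured and on what is new or still open speak of the compounds shown alone.

Compound 3 `Cc1ccc(NC(=O)Nc2nn(-c3ccccc3)c(=O)c3ccccc23)cc1` carries a 4-methylphenyl on an amide-type nitrogen and stands at the top of the three numbers in an assay on CHO cells for displacement of a labelled ligand from adenosine receptor A1 (Homo sapiens), tested at 10 uM (on this read-out lower numbers stand for less inhibition and higher numbers for more inhibition at the one concentration tested (going by the name of the read-out)), where compound 3 gives 29%. Compound 2 `O=C(Nc1nn(-c2ccccc2)c(=O)c2ccccc12)c1ccco1` comes nearest, giving 23%, a gap within the scatter, while compound 1 `COc1ccc(OC)c(NC(=O)Nc2nn(-c3ccccc3)c(=O)c3ccccc23)c1` sits furthest, giving 0%; a number 29 percentage points higher from compound 1 to compound 3 (beyond the scatter). The step of a number 6 percentage points higher from compound 2 to compound 3 (within the scatter) alters a different part of the molecule and bears little on the present question. Compound 4 `Cc1ccccc1NC(=O)Nc1nn(-c2ccccc2)c(=O)c2ccccc12` differs from compound 3 by 2-methylphenyl in place of 4-methylphenyl on an amide-type nitrogen. Within the data shown here, only the step from compound 1 touches this place, and it was modest yet beyond the scatter, so a shift of similar order in either direction would not surprise. Compound 4 is therefore expected to give 20% in this assay, within 0% to 45%, an expected step of a number 9 percentage points lower from compound 3 to compound 4 (within the scatter).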

Compound 4, a percentage reported as inhibition, at one concentration (the size of the read-out at that concentration, not a potency): 20%
The estimate for compound 4 equals the measured number at the digits printed, and the stated range covers the measured number.
By their numbers in this assay, from the lowest: compound 1; then compounds 4, 2 and 3 (each within the scatter of the next).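

In this assay the shift of the methyl group from 4-methylphenyl to 2-methylphenyl on the amide-type nitrogen gives a number 9 percentage points lower from compound 3 to compound 4 (within the scatter) and so shows that this move leaves the number within the scatter. Against furan-2-yl on the carbonyl carbon, (2-methylphenyl)amino gives a number 3 percentage points lower from compound 2 to compound 4 (within the scatter) as well, whereas 2-methylphenyl in place of 2,5-dimethoxyphenyl gives a number 20 percentage points higher from compound 1 to compound 4 (beyond the scatter) and remains a real separation. Nothing available explains these numbers.

On these data alone, whether an unsubstituted phenyl or a single methoxyphenyl on this nitrogen would stand with the methylphenyl compounds or with compound 1 remains open.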